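Swapping pyridin-2-yl for 1,3-benzothiazol-2-yl on a sulfur

A few compounds are considered here, and "the series" means these few. Any claim that something is new, unique, unknown or untested is made for them only; others in the source may bear on it.

In a functional assay on SGC-7901 cells (Homo sapiens) for cytotoxicity, read by MTT assay, with a stated time of 48 h (on this read-out higher numbers stand for weaker inhibition and lower numbers for stronger inhibition), compound 1 `CC1=NN(C(=O)CSc2ccccn2)[C@@H](c2cc(Br)cc(Br)c2O)C1` gives 10300 nM and stands level with compound 2 `O=C(CSCc1ccco1)N1N=C(c2cc3ccccc3oc2=O)C[C@@H]1c1ccccc1C(F)(F)F` at 10300 nM on the numbers. For the measured compounds named here, compound 3 `O=C(CSc1ccc(Br)cc1)N1N=C(c2cc3ccccc3oc2=O)C[C@@H]1c1ccc(C(F)(F)F)cc1` gives 12100 nM and lies within the usual scatter of both, so no compound of the three stands apart.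

The next structure, compound 4 `CC1=NN(C(=O)CSc2nc3ccccc3s2)[C@@H](c2cc(Br)cc(Br)c2O)C1` keeps the core of compound 1 and changes one group: 1,3-benzothiazol-2-yl in place of pyridin-2-yl on a sulfur In words, 1,3-benzothiazol-2-yl takes the place of pyridin-2-yl on a sulfur. Going by the values given here, no pair of measured compounds isolates this change, so its effect in this assay cannot be read directly from the data.

The close values of compound 1 (10300 nM) and compound 3 (12100 nM) give no hint of a large swing, although these two structures differ in many places. The expected change, a 1.4-fold lower number from compound 1 to compound 4 (0.14 log units; within the scatter) is therefore a small one towards stronger inhibition, and it may well stay within the scatter. For compound 4 the estimated value is 7500 nM with 2500 nM to 20000 nM as its expected range.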

Compound 4, half-maximal inhibitory concentration: 12300 nM
Compound 4: the middle estimate sits 1.6-fold (0.21 log units) below what was measured, within the range that was stated.
By their numbers in this assay, from the lowest: compounds 1, 2, 3 and 4 (each within the scatter of the next).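

For the compounds shown here, this is the first direct reading at this position: with the rest of compound 1 kept, 1,3-benzothiazol-2-yl in place of pyridin-2-yl on a sulfur gives a small step in this assay (a 1.2-fold higher number from compound 1 to compound 4 (0.08 log units; within the scatter)) . The group on the sulfur can thus go from 6 heavy atoms to 9 heavy atoms, with a second aromatic ring, and the read-out stays within the usual scatter. Nothing available explains why the two groups read alike.

Going by these compounds, both groups tested here are aromatic rings, so it remains open how a carboxylic acid, an amine or a longer saturated chain would read in that place. This single pair also leaves open whether the same swap would read alike on the core of compound 2 or compound 3.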